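Benzylamino for aminomethyl on the shared core

A few compounds are considered here, and "the series" means these few. Any claim that something is new, unique, unknown or untested is made for them only; others in the source may bear on it.

Measured compounds:
compound 1, `Cc1nc2c(OCc3ccccc3)cccn2c1CN`, 49%
compound 2, `CCNc1c(C)nc2c(CCc3ccccc3)cccn12`, 11%

The account concerns two measured compounds and one that is not yet measured. In a functional assay on the whole organism with Canis familiaris (Canis lupus familiaris) as the target, at a dose of 5 mg/kg by the intravenous route (on this read-out higher numbers stand for a stronger effect at the one dose given and lower numbers for a weaker effect), compound 1 gives 49%, the higher of the two numbers. Among the measured compounds shown here, compound 2 gives 11% in this assay, a number well below that of compound 1 and beyond the scatter; no single-point step between them is set out, and the two structures differ in more than one place, so only the two values themselves can be compared.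

Compound 3, `Cc1nc2c(OCc3ccccc3)cccn2c1NCc1ccccc1`, remains to be measured in this assay. It differs from compound 1 in one place: benzylamino in place of aminomethyl on an aromatic carbon. For the measured compounds named here, no step between measured compounds involves this change, so the size of the step is open. Since compound 2 also carries a substituted amine on that carbon and gives 11%, a moderate fall from compound 1 to compound 3 is expected rather than a gain. The expected step is a number 19 percentage points lower from compound 1 to compound 3 (beyond the scatter). Compound 3 is estimated at 30%, with a range from 8% to 55%.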

Compound 3, a percentage reported as inhibition, in the whole organism at one dose (the size of the read-out at that dose, not a potency): 0%
Compound 3: middle estimate off by 30 percentage points, on the high side; the whole stated range lies above it.
By their numbers in this assay, from the lowest: compound 3; then compound 2; then compound 1.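

In this assay, placing benzylamino instead of aminomethyl on this aromatic carbon of the five-membered aromatic ring gives a number 49 percentage points lower from compound 1 to compound 3 (beyond the scatter), the first single-place step read at this position, and it shows that the effect seen with compound 1 at the one dose given is highly sensitive to the group held here. The group that enters has the same count of hydrogen-bond donors and acceptors as the group that leaves and carries no net charge, so the large step comes with a change that these counts do not register: more heavy atoms and an added six-membered aromatic ring of carbon only. No measurement offered here bears on why the effect is lost.

The one step changes the link to the ring and adds the aromatic ring together, so the compounds shown cannot tell these two changes apart. From the compounds shown here alone, whether a plain amine, a methylamino group or a longer chain such as aminoethyl on this carbon would retain the effect of compound 1 remains open.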